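Iodo to Methyl on the Shared Core

The source may report more compounds than this note shows. Statements on the series, on what has been measured and on what is new or still open speak of the compounds shown alone.

For the measured compounds named here, compound 2 `Nc1nc(N)nc(-c2ccccc2I)n1` stands at the top of the two numbers measured so far. In a physicochemical assay for lipophilicity (a higher number here means a more lipophilic compound, a lower number a more polar compound), compound 2 gives 1.41. Going by the values given here, compound 1 `Nc1nc(N)nc(-c2ccccc2[N+](=O)[O-])n1` gives 0.49 in this assay, and the step of a number 0.92 log units higher from compound 1 to compound 2 (beyond the scatter) is the only measured change available. Compound 3 `Cc1ccccc1-c1nc(N)nc(N)n1` has not yet been measured. It differs from compound 2 in one place: methyl in place of iodo on an aromatic carbon. Among the compounds with values here, no measured step swaps iodo for methyl, so the nitro-to-iodo step offers no direct guide; it shows only that a change at this position can move this assay by a modest amount. With nothing pointing to a rise, a modest decrease is expected. Compound 3 is therefore expected to give 0.9 in this assay, within a range from 0.5 to 1.3. This amounts to an expected step of a number 0.51 log units lower from compound 2 to compound 3 (beyond the scatter).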

Compound 3, partition coefficient: 1.26
For compound 3 the middle estimate is 0.36 log units below the measured one; measured number inside the range.
By their numbers in this assay, from the lowest: compound 1; then compounds 3 and 2 (each within the scatter of the next).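

In this assay, methyl in place of iodo on this aromatic carbon gives a number 0.15 log units lower from compound 2 to compound 3 (within the scatter), so these two groups cannot be told apart here. Methyl in place of nitro gives a number 0.77 log units higher from compound 1 to compound 3 (beyond the scatter), so two different groups now each stand a modest step away from nitro, and compound 1 remains the lowest of the three. No measured evidence accounts for these numbers, and why they fall this way stays unknown.

As far as these compounds go, whether an amine, a carboxylic acid or a longer chain at this place would sit with compound 2 and compound 3, sit near compound 1 or land elsewhere remains open. Also open, from the compounds shown here alone, is whether the same swaps would give similar steps at another place on the shared core.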